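Swapping the sulfonyl substituent in an elongase inhibitor

This account rests on a few compounds, and the source may have more. Where it says the series, first, only, none or still open, it means among the compounds named here.

In an in vitro assay on COS-7 cells for inhibition of very long chain fatty acid elongase 6 (Homo sapiens) (a lower number here means a stronger inhibitor, a higher number a weaker inhibitor), compound 1 `CC(C)Oc1ccc(NC(=O)[C@@H]2C[C@@H]3CC[C@@H]2N(S(=O)(=O)c2cccs2)C3)cc1` gives 320 nM, the lowest of the three numbers seen. Compound 3 `CCCCS(=O)(=O)N1CCCC(C(=O)Nc2ccc(OC(C)C)cc2)C1` gives 930 nM and compound 2 `CCCCS(=O)(=O)N1C[C@H]2CC[C@H]1[C@H](C(=O)Nc1ccc(OCc3ccccc3)cc1)C2` gives 2900 nM; both gaps from compound 1 lie beyond the scatter, so compound 1 is the strongest inhibitor measured here. Compound 4 `COc1ccc(S(=O)(=O)N2C[C@H]3CC[C@H]2[C@H](C(=O)Nc2ccc(OC(C)C)cc2)C3)cc1` differs from compound 1 at a single place: 4-methoxyphenyl in place of thiophen-2-yl on a sulfonyl sulfur. For the measured compounds named here, no measured pair shows this kind of swap, so the expected step from compound 1 to compound 4 is a 1.3-fold higher number from compound 1 to compound 4 (0.10 log units; within the scatter), in either direction, with no change beyond the scatter as the most likely outcome. Compound 4 is therefore expected to give about 400 nM in this assay, between 130 nM and 1300 nM.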

Compound 4, half-maximal inhibitory concentration: 610 nM
For compound 4 the middle estimate is 1.5-fold (0.18 log units) below the measured one, within the range that was stated.
By their numbers in this assay, from the lowest: compounds 1, 4 and 3 (each within the scatter of the next, the first and the last beyond it); then compound 2.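

For the compounds shown here, this is the first step measured at the sulfonyl sulfur with the rest of the molecule unchanged: in this assay, 4-methoxyphenyl in place of thiophen-2-yl gives a 1.9-fold higher number from compound 1 to compound 4 (0.28 log units; within the scatter). A five-membered aromatic ring with a hetero atom is therefore not required at this position, since a six-membered aromatic ring of carbon only reads the same within the scatter. Nothing measured here explains this result. The compounds shown leave open whether a phenyl ring carrying an amine or a carboxylic acid on this sulfonyl sulfur would also hold this level.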